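A Butyl Chain on the Ring Nitrogen

The source may hold more compounds than are shown below. What is called first, only, known or untested is meant among the compounds shown, and "the series" means these compounds.

Three compounds of this series have been measured in a functional assay for antagonist activity at 5-hydroxytryptamine receptor 4 (Cavia porcellus); on this read-out lower numbers stand for lower potency and higher numbers for higher potency (the scale is a negative logarithm):

Compound 1 `CN1CCN(CCCNC(=O)n2c(=O)n(C3CC3)c3ccccc32)CC1` gives 6.4.
Compound 2 `CN1CCN(CCNC(=O)n2c(=O)[nH]c3ccccc32)CC1` gives < 6.
Compound 3 `CCCn1c(=O)n(C(=O)NCCN2CCN(C)CC2)c2ccccc21` gives < 6.

Compound 2 stands at a limit of this assay: the value < 6 is a limit and not a number. The same holds for compound 3, whose value < 6 is also a limit. Compound 1, which carries a cyclopropyl on the aromatic nitrogen and a longer linker, gives 6.4 in this assay. Going by the values given here, the one measured step that bears on the change studied here, a step that the two limits leave unreadable from compound 2 to compound 3, cannot be read, since (the limit of < 6 in this assay, at which 2 of the 3 values shown sit).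

Compound 4 `CCCCn1c(=O)n(C(=O)NCCN2CCN(C)CC2)c2ccccc21` differs from compound 2 as follows: butyl in place of hydrogen on an aromatic nitrogen. Compound 3, with a propyl at the same place, stayed at the limit, so no gain beyond the scatter is expected; the expected step that the limit leaves unreadable from compound 2 to compound 4 is therefore taken as small. For compound 4 the estimate in this assay is 5.8, with a range from 5.2 to 6.5.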

Compound 4, negative logarithm of the antagonist equilibrium constant: < 6
Compound 4 was reported as a limit (the forecaster's own chance of this, stated with the estimate: 60%); the middle value is on the limit's open side.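

Compound 4 gives < 6 in this assay, which is a limit and not a number. Going by these compounds alone, no step among compound 2, compound 3 and compound 4 can be read, because all three sit at that limit: the limit of < 6 in this assay, at which 3 of the 4 values shown sit. Going by these compounds, whether a propyl or butyl on the aromatic nitrogen changes potency at all stays open.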